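The source may hold more compounds than are shown below. What is called first, only, known or untested is meant among the compounds shown, and "the series" means these compounds.

Measured compounds:
compound 1 `CN(C)c1ccc(N2C(=O)NC3(CSC4=C3C(=O)c3ncccc3C4=O)C2=O)cc1`: 1 nM
compound 2 `O=C1NN(c2ccc([N+](=O)[O-])cc2)C(=O)C2(CSC3=C2C(=O)c2ncccc2C3=O)N1`: 2 nM

In a functional assay on CCRF-CEM cells (Homo sapiens) for antiproliferative activity, read by MTT assay, with a stated time of 96 h (on this read-out lower numbers stand for stronger inhibition and higher numbers for weaker inhibition), compound 1 gives 1 nM, the lower of the two numbers, while compound 2 gives 2 nM; the gap between them is within the scatter, so no order is drawn from it. Compound 3 `O=C1C2=C(C(=O)c3ncccc31)C1(CS2)NC(=O)N(c2ccncc2)C1=O` has not yet been measured. It differs from compound 1 in one place: pyridin-4-yl in place of 4-(dimethylamino)phenyl on an amide-type nitrogen in a ring. For the measured compounds named here, no pair of measured compounds differs at this position, so the series holds no measured step from which the size of this change could be read. With nothing measured against it, a step in this assay beyond the scatter cannot be ruled out either way; a small rise in the number, meaning somewhat weaker inhibition, is taken as the working expectation. Compound 3 is therefore expected to give about 3 nM, between 1 nM and 12 nM, which corresponds to an expected step of a 3.0-fold higher number from compound 1 to compound 3 (0.48 log units; beyond the scatter).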

Compound 3, half-maximal inhibitory concentration: 2 nM
The estimate for compound 3 lay 1.5-fold (0.18 log units) above the measured number, within the range that was stated.
By their numbers in this assay, from the lowest: compounds 1, 2 and 3 (each within the scatter of the next).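

In this assay, for the compounds shown here, the first measured step at this position, pyridin-4-yl in place of 4-(dimethylamino)phenyl on the amide-type nitrogen in the ring, gives a 2.0-fold higher number from compound 1 to compound 3 (0.30 log units; within the scatter). At this nitrogen, then, a six-membered aromatic ring with 1 hetero atom and a six-membered aromatic ring of carbon only bearing dimethylamino show no difference beyond the scatter, so in this pair the dimethylamino group is not required for a value at this level. Nothing on hand explains the size of this step.

As far as these compounds go, how an unsubstituted phenyl, pyridin-3-yl or a saturated ring such as cyclohexyl would read at this nitrogen remains open. Also open, from the compounds shown here alone, is whether a simple chain such as n-butyl would hold a value at this level on the same core.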